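Trading an amino link for an ether on compound 3

This account rests on a few compounds, and the source may have more. Where it says the series, first, only, none or still open, it means among the compounds named here.

Three related compounds have been measured in a functional assay on RS4-11 cells (Homo sapiens) for inhibition, read by CCK-8 assay, with a stated time of 72 h; a lower number here means a stronger inhibitor, a higher number a weaker inhibitor. In it, compound 1 (`CC1(C)CCC(CN2CCN(c3ccc(C(=O)NS(=O)(=O)c4ccc(NCC5CCOCC5)c([N+](=O)[O-])c4)c(Oc4cnc5[nH]ccc5c4)c3)CC2)=C(c2ccccc2C(F)(F)F)C1`) gives 18 nM, compound 2 (`CC(C)C(=O)N1CCC(CNc2ccc(S(=O)(=O)NC(=O)c3ccc(N4CCN(CC5=C(c6ccc(C(F)(F)F)cc6)CC(C)(C)CC5)CC4)cc3Oc3cnc4[nH]ccc4c3)cc2[N+](=O)[O-])CC1`) gives 5.3 nM, and compound 3 (`CC1(C)CCC(CN2CCN(c3ccc(C(=O)NS(=O)(=O)c4ccc(NC5CCOC5)c([N+](=O)[O-])c4)c(Oc4cnc5[nH]ccc5c4)c3)CC2)=C(c2ccc(C(F)(F)F)cc2)C1`) gives 32 nM. Compound 3 therefore stands within the usual scatter of compound 1, and it is clearly a weaker inhibitor than compound 2.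

Compound 4 (`CN1CCC(COc2ccc(S(=O)(=O)NC(=O)c3ccc(N4CCN(CC5=C(c6ccc(C(F)(F)F)cc6)CC(C)(C)CC5)CC4)cc3Oc3cnc4[nH]ccc4c3)cc2[N+](=O)[O-])C1`) is still unmeasured and differs from compound 3 in one place: (1-methylpyrrolidin-3-yl)methoxy in place of (oxolan-3-yl)amino on an aromatic carbon. The new group sits on an aromatic carbon of a six-membered aromatic ring of carbon only, ortho to a nitro group and para to a large group.

For the measured compounds named here, only one measured step involves this position: a 6.0-fold higher number from compound 2 to compound 3 (0.78 log units; beyond the scatter). That step exchanged one group on the nitrogen for another, and it moved the number only modestly. Going by the values given here, no measured compound carries an oxygen link here, so the data give no direction for this change. With that single modest step as the guide, no step beyond the scatter is expected in this assay, though with real uncertainty. The expected step is a 1.5-fold lower number from compound 3 to compound 4 (0.16 log units; within the scatter). For compound 4 the estimated value is 22 nM, with an expected range from 6 nM to 80 nM.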

Compound 4, half-maximal inhibitory concentration: 10 nM
For compound 4 the middle estimate is 2.2-fold (0.34 log units) above the measured one; low and high end bracket the measured number.
By their numbers in this assay, from the lowest: compounds 2, 4, 1 and 3 (each within the scatter of the next, the first and the last beyond it).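

In this assay, for the compounds shown here, the change brought a clear gain (a 3.2-fold lower number from compound 3 to compound 4 (0.51 log units; beyond the scatter)), which shows that this position tolerates an oxygen link where the earlier compounds carried only a nitrogen link. The entering (1-methylpyrrolidin-3-yl)methoxy counts 0 hydrogen-bond donors against 1 for the leaving (oxolan-3-yl)amino, and the number still fell, so a donor on this link is not needed for a low number in this series. Nothing measured here explains the gain, and the oxygen link, the larger group and the swap of the ring oxygen for a methylated ring nitrogen all arrived together, so their separate shares cannot be told apart.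

Whether the gain follows the oxygen link or the ring nitrogen stays open, since an (oxolan-3-yl)methoxy group and a (1-methylpyrrolidin-3-yl)methylamino group, which would each change only one of the two, are not among the compounds shown. Also open, on these data alone, is how far the position accepts other ether groups, from a plain methoxy to a longer chain ending in a dimethylamine.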